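Methoxyphenyl Triazole Variant Awaits Its Cytotoxicity Readout

A few compounds are considered here, and "the series" means these few. Any claim that something is new, unique, unknown or untested is made for them only; others in the source may bear on it.

Of the compounds shown here, three from one series have been measured in an ADME assay on HFF cells (Homo sapiens) for cytotoxicity, read by MTT assay, with a stated time of 72 h; on this read-out lower numbers stand for stronger inhibition and higher numbers for weaker inhibition. Compound 1 `CC(C)(C)c1cn(C[C@H](O)[C@H]2OC(=O)C(OCc3ccccc3)=C2OCc2ccccc2)nn1` gives 13300 nM. Compound 2 `O=C1O[C@H]([C@@H](O)Cn2cc(-c3cccc(O)c3)nn2)C(OCc2ccccc2)=C1OCc1ccccc1` gives 39000 nM. Compound 3 `C[Si](C)(C)c1cn(C[C@H](O)[C@H]2OC(=O)C(OCc3ccccc3)=C2OCc2ccccc2)nn1` gives 20000 nM. Among these three numbers compound 3 stands second highest; its nearest neighbour is compound 1 and its furthest is compound 2, with a 1.5-fold higher number from compound 1 to compound 3 (0.18 log units; within the scatter) and a 2.0-fold lower number from compound 2 to compound 3 (0.29 log units; within the scatter), neither of which leaves the scatter. Within the data shown here, the only step that does is a 2.9-fold higher number from compound 1 to compound 2 (0.47 log units; beyond the scatter).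

Compound 4 `COc1ccc(-c2cn(C[C@H](O)[C@H]3OC(=O)C(OCc4ccccc4)=C3OCc3ccccc3)nn2)cc1` is the unmeasured member. Relative to compound 3 it carries a group of 8 heavy atoms (7 carbon, 1 oxygen; one six-membered aromatic ring of carbon only) in place of a group of 4 heavy atoms (3 carbon, 1 silicon; no ring), on an aromatic carbon. Among the measured compounds shown here, two measured steps bear on this change. The step in which a 2.0-fold lower number from compound 2 to compound 3 (0.29 log units; within the scatter) is the reverse kind of exchange, a six-membered aromatic ring leaving for the silicon group, and it stayed within the scatter. The step in which a 2.9-fold higher number from compound 1 to compound 2 (0.47 log units; beyond the scatter) introduced a six-membered aromatic ring on an aromatic carbon and produced a modest rise. Together they suggest that 4-methoxyphenyl in place of the silicon group will give compound 4 a somewhat higher number, of modest size at most, and possibly one that does not leave the scatter. Compound 4 is therefore expected to show 30000 nM, within a range from 15000 nM to 60000 nM. This estimate corresponds to an expected step of a 1.5-fold higher number from compound 3 to compound 4 (0.18 log units; within the scatter).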

Compound 4, half-maximal inhibitory concentration: < 10 nM
Compound 4: a limit, no number; the forecaster's own chance of this, stated with the estimate: 10%; at least 3000-fold (3.47 log units) between middle value and limit.
By their numbers in this assay, from the lowest: compounds 1, 3 and 2 (each within the scatter of the next, the first and the last beyond it). At a limit, below all of these: compound 4.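

Among these compounds, the position on the aromatic carbon of the five-membered ring had so far moved the number in this assay only modestly, but it can carry a far larger change: 4-methoxyphenyl in place of the silicon group gives an at least 2000-fold lower number from compound 3 to compound 4 (3.30 log units; beyond the scatter). The change does not follow from having a six-membered aromatic ring at this place, as compound 2 also has one, yet 4-methoxyphenyl in place of 3-hydroxyphenyl gives an at least 3900-fold lower number from compound 2 to compound 4 (3.59 log units; beyond the scatter), and 4-methoxyphenyl in place of tert-butyl gives an at least 1300-fold lower number from compound 1 to compound 4 (3.12 log units; beyond the scatter). The result for compound 4 is a limit of the assay and not a number: the limit of < 10 nM in this assay, at which 1 of the 4 values shown sits.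

Whether a plain phenyl, a 3-methoxyphenyl or a 4-hydroxyphenyl at this place would stay close to compound 2 or follow compound 4 remains open, so the compounds shown cannot separate the methoxy group from its place on the aromatic ring. From the compounds shown here alone, how far compound 4 lies beyond its limit also remains open, and with it the true size of all three steps.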